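This account rests on a few compounds, and the source may have more. Where it says the series, first, only, none or still open, it means among the compounds named here.

Three compounds share one core and differ only in the group on an aromatic nitrogen. Compound 1 `COC(CCn1cnc2c(NCc3ccc(C(=O)Nc4ccccc4N)cc3)nc(Cl)nc21)OC` gives 51.2% in a functional assay on NCI-H460 cells (Homo sapiens) for antiproliferative activity, read by CCK-8 assay, with a stated time of 72 h, tested at 8 uM; a higher number here means a stronger effect of the compound at the concentration tested, a lower number a weaker effect; compound 2 `CC(C)n1cnc2c(NCc3ccc(C(=O)Nc4ccccc4N)cc3)nc(Cl)nc21` gives 80.5%; compound 3 `Nc1ccccc1NC(=O)c1ccc(CNc2nc(Cl)nc3c2ncn3C2CCCC2)cc1` gives 57.4%. Compound 3 stands second highest of the three: its gap to compound 1 lies within the scatter, while the step of a number 23.1 percentage points lower from compound 2 to compound 3 (beyond the scatter) lies beyond it. Compound 4 `Nc1ccccc1NC(=O)c1ccc(CNc2nc(Cl)nc3c2ncn3Cc2ccccc2)cc1` differs from compound 3 by benzyl in place of cyclopentyl on an aromatic nitrogen. Among the measured compounds shown here, the steps that bear on this place are a number 29.3 percentage points higher from compound 1 to compound 2 (beyond the scatter), a number 6.2 percentage points higher from compound 1 to compound 3 (within the scatter) and a number 23.1 percentage points lower from compound 2 to compound 3 (beyond the scatter), yet none of them brings in a benzyl, so they set no direction for this change. The expected step of a number 2.4 percentage points lower from compound 3 to compound 4 (within the scatter) is therefore small, with wide uncertainty. Compound 4 is estimated at 55%, in the range 35% to 75%.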

Compound 4, a percentage reported as inhibition, at one concentration (the size of the read-out at that concentration, not a potency): 46.4%
Estimate against measurement, compound 4: 8.6 percentage points above; low and high end bracket the measured number.
By their numbers in this assay, from the lowest: compounds 4, 1 and 3 (each within the scatter of the next, the first and the last beyond it); then compound 2.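

In this assay the value sits a number 11 percentage points lower from compound 3 to compound 4 (beyond the scatter) once benzyl replaces cyclopentyl, so swapping one ring for the other at this position is not neutral. It also sits a number 34.1 percentage points lower from compound 2 to compound 4 (beyond the scatter) with benzyl in place of isopropyl and a number 4.8 percentage points lower from compound 1 to compound 4 (within the scatter) against the 3,3-dimethoxypropyl compound, which leaves isopropyl clear of all three other groups. Nothing available explains these steps. Going by these compounds, whether ethyl or tert-butyl would match isopropyl stays open, as does the effect of a chain ending in an amine or a carboxylic acid.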